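Methyl on the aniline ring in two enaminone series

The source may report more compounds than this note shows. Statements on the series, on what has been measured and on what is new or still open speak of the compounds shown alone.

Measured so far, in a functional assay on MIA PaCa-2 cells (Homo sapiens) for antiproliferative activity, read by sulforhodamine B assay, with a stated time of 48 h; on this read-out higher numbers stand for weaker inhibition and lower numbers for stronger inhibition:
compound 1 `COc1ccc2nc(-c3ccc(N/C=C\C(=O)c4cc(OC)c(OC)c(OC)c4)c(C)c3)sc2c1`: 10000 nM
compound 2 `COc1ccc2nc(-c3ccc(N/C=C\C(=O)c4cc(OC)c(OC)c(OC)c4)cc3)sc2c1`: 31100 nM
compound 3 `COc1ccc2nc(-c3ccc(N/C=C\C(=O)c4ccc(OC)c([N+](=O)[O-])c4)cc3)sc2c1`: 23600 nM

Compound 2 and compound 1 share one core and differ in a single place: methyl in place of hydrogen on an aromatic carbon. Among the measured compounds shown here, that change gave a 3.1-fold lower number from compound 2 to compound 1 (0.49 log units; beyond the scatter), a step beyond the scatter, and it is the only instance of the change measured so far.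

Compound 3 carries a different aryl ketone part than compound 2; the difference between the two cores is not broken down here. In this assay compound 3 and compound 2 read within the scatter of each other, so no order between them can be stated. Compound 3 does read higher than compound 1 by a step beyond the scatter.

Compound 4 `COc1ccc2nc(-c3ccc(N/C=C\C(=O)c4ccc(OC)c([N+](=O)[O-])c4)c(C)c3)sc2c1` is not yet measured. It stands to compound 3 as compound 1 stands to compound 2: methyl in place of hydrogen on an aromatic carbon. The surroundings of the place are described in the same words for both pairs, so this is the same change on a different core.

For this assay the step is expected to be a 3.0-fold lower number from compound 3 to compound 4 (0.47 log units; beyond the scatter). For the measured compounds named here, the expectation rests on the one earlier instance, which gave a 3.1-fold lower number from compound 2 to compound 1 (0.49 log units; beyond the scatter), and is held wider than that step since a single pair on another core gives no certainty that it carries over. Compound 4 is thus estimated at 8000 nM, between 3000 nM and 22000 nM.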

Compound 4, half-maximal inhibitory concentration: 23600 nM
Compound 4: middle estimate off by 3.0-fold (0.47 log units), on the low side; measured number outside the range, above it.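

Working notes on the methyl step. In this assay, methyl in place of hydrogen on the same aromatic carbon gave no change at the digits printed from compound 3 to compound 4 (within the scatter), so the step seen on the core of compound 2 did not carry over to the core of compound 3, and the two instances disagree: the same change on two cores in this assay, a 3.1-fold lower number (0.49 log units; beyond the scatter) from compound 2 to compound 1 and no change at the digits printed (within the scatter) from compound 3 to compound 4, 3.1-fold (0.49 log units) apart, beyond the scatter of two such steps. This shows that, in this series, the result of this methyl change cannot be read across from one core to the other, and that a step measured on a single pair is a poor basis for an estimate on a second core. Among the compounds shown here, it does not show which feature of the aryl ketone part separates the two outcomes, since the two cores differ in more than one substituent on that part, nor does it give a rule for any further core, since only two pairs are in hand.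

Still open, as far as these compounds go, is whether a chlorine atom or an ethyl group at the same aromatic carbon would follow the pair of compound 2 and compound 1 or the pair of compound 3 and compound 4. Also open, from the compounds shown here alone, is how the methyl step would read on a core carrying an amine in place of the nitro group of compound 3.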